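An Ester Replaces a Methylbenzyl Group

The compounds below may be only part of what the source reports. "The series", "measured", "known", "first", "only" and "open" are said of these compounds alone.

Of the compounds shown here, three sharing one core have been tested in a functional assay on CHO-K1 cells for antagonist activity at transient receptor potential cation channel subfamily V member 1 (Homo sapiens), read by FLIPR; a lower number here means a stronger inhibitor, a higher number a weaker inhibitor. Compound 1 `CC1CCC(Nc2nc(C(F)(F)F)ccc2CNC(=O)C(C)c2ccc(NS(C)(=O)=O)c(F)c2)CC1` gives 27.2 nM. Compound 2 `CCCN(CCC)c1nc(C(F)(F)F)ccc1CNC(=O)C(C)c1ccc(NS(C)(=O)=O)c(F)c1` gives 0.2 nM, and compound 3 `Cc1ccc(CC2CCN(c3nc(C(F)(F)F)ccc3CNC(=O)C(C)c3ccc(NS(C)(=O)=O)c(F)c3)CC2)cc1` gives 0.2 nM. Among the measured compounds shown here, only one pair differs in a single place, and that step is a 140-fold lower number from compound 1 to compound 2 (2.13 log units; beyond the scatter). Compound 3 stands level with compound 2 at the digits shown; together they hold the lowest numbers of the three, while compound 1 sits far higher.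

Compound 4 `CC(C(=O)NCc1ccc(C(F)(F)F)nc1N1CCC(OC(=O)C(C)(C)C)CC1)c1ccc(NS(C)(=O)=O)c(F)c1` is not yet measured. It differs from compound 3 in one place: ((tert-butyl)carbonyl)oxy in place of 4-methylbenzyl on a saturated ring carbon. For the measured compounds named here, no measured step touches this position, so the data give no direct guide to the size of this swap. Going by the values given here, the single measured step concerns a different part of the shared core and shows only that this region of the molecule can move the number by a large amount.

Compound 4 is therefore expected to land near 1 nM, with a plausible range from 0.2 nM to 6 nM. That estimate amounts to an expected step of a 5.0-fold higher number from compound 3 to compound 4 (0.70 log units; beyond the scatter), a modest weakening that may or may not exceed the usual scatter.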

Compound 4, inhibition constant: 2 nM
For compound 4 the middle estimate is 2.0-fold (0.30 log units) below the measured one, within the range that was stated.
By their numbers in this assay, from the lowest: compounds 2 and 3 (each within the scatter of the next); then compound 4; then compound 1.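

In this assay, among the compounds shown here, placing ((tert-butyl)carbonyl)oxy in place of 4-methylbenzyl on the saturated ring carbon gives a 10-fold higher number from compound 3 to compound 4 (1.00 log units; beyond the scatter), the first measured step at this position, and it shows that the number responds to what this carbon carries. The change removes the six-membered aromatic ring and adds a carbonyl-containing group with two hydrogen-bond acceptors, yet compound 4 still reads 2 nM, so within this pair a low number does not depend on keeping an aromatic ring at this place. No measurement is available to explain the rise in the number, so it cannot be tied to any property of either group.

The swap alters several features at once, so this single pair cannot separate the loss of the aromatic ring from the arrival of the ester oxygens and the tert-butyl group. As far as these compounds go, it also remains open where a simple hydroxyl group, an amine or a benzyl ether on this same ring carbon would fall relative to compound 3 and compound 4.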